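The source may report more compounds than this note shows. Statements on the series, on what has been measured and on what is new or still open speak of the compounds shown alone.

Measured compounds:
compound 1, `CCc1nc(-c2ccc(Cl)cc2Cl)c(CC)nc1NC(COC)COC`, which in an assay on IMR-32 cells for displacement of a labelled ligand from corticotropin-releasing factor receptor 1 (Homo sapiens), read by scintillation counting, with a stated time of 2 h (a higher number here means a weaker inhibitor, a lower number a stronger inhibitor), gives 224 nM
compound 2, `CCc1nc(N(CC2CC2)CC2CC2)c(CC)nc1-c1ccc(Cl)cc1Cl`, which in this assay gives 26 nM

Among the measured compounds shown here, compound 2 gives the lower of the two numbers; the single recorded step, an 8.6-fold lower number from compound 1 to compound 2 (0.94 log units; beyond the scatter), is the only guide to how this part of the shared core responds to change.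

Compound 3, `CCc1nc(-c2ccc(Cl)cc2Cl)c(CC)nc1CC(CC)CC`, carries the change (2-ethylbutyl in place of bis(cyclopropylmethyl)amino on an aromatic carbon). The recorded step exchanged one nitrogen-linked group for another, so it bears only loosely on this exchange, in which the nitrogen link itself is given up for a branched carbon chain. For the measured compounds named here, with no closer precedent, a small to modest rise in the number is expected, a 2.3-fold higher number from compound 2 to compound 3 (0.36 log units; beyond the scatter), rather than a further fall. Compound 3 is therefore estimated at 60 nM, with a likely range from 15 nM to 250 nM.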

Compound 3, inhibition constant: 68 nM
Beside the measured number, compound 3's estimate is 1.1-fold (0.05 log units) below it, within the range that was stated.
By their numbers in this assay, from the lowest: compound 2; then compound 3; then compound 1.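

In this assay, the nitrogen link at this position proves not to be essential for a fairly low number. Replacing bis(cyclopropylmethyl)amino with 2-ethylbutyl, which has no nitrogen and no ring, gives only a modest loss, seen as a 2.6-fold higher number from compound 2 to compound 3 (0.42 log units; beyond the scatter) in the step. The same carbon chain still outperforms the (2-methoxy-1-(methoxymethyl)ethyl)amino group, with a 3.3-fold lower number from compound 1 to compound 3 (0.52 log units; beyond the scatter) as the step, while no separate measurement accounts for this order of the three groups.

From the compounds shown here alone, it remains open whether the loss from compound 2 to compound 3 follows from giving up the nitrogen, the two cyclopropane rings, or the overall size of the group. A dipropylamino group or a bis(cyclopropyl)methyl group, joined directly through carbon, would help separate these features.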